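Boronic acid isomer at the weak end of the series

The compounds below may be only part of what the source reports. "The series", "measured", "known", "first", "only" and "open" are said of these compounds alone.

In a functional assay on B16 cells (Mus musculus) for inhibition (a lower number here means a stronger inhibitor, a higher number a weaker inhibitor), compound 1 `CC(C)CN(NC(=O)OCc1ccccc1)C(=O)CN(Cc1ccccc1)NC(=O)CBr` gives 1800 nM, compound 2 `CC(C)CN(NC(=O)OCc1ccccc1)C(=O)CN(Cc1ccccc1)NC(=O)Cc1cccc(Br)c1` gives 15800 nM and compound 3 `CC(C)CN(NC(=O)OCc1ccccc1)C(=O)CN(Cc1ccccc1)/N=C/c1ccccc1B(O)O` gives 45100 nM, the highest number of the three and the weakest inhibitor so far. Compound 4 `CC(C)CN(NC(=O)OCc1ccccc1)C(=O)CN(Cc1ccccc1)/N=C/c1cccc(B(O)O)c1` has the same atoms as compound 3, joined differently: a group of 9 heavy atoms (6 carbon, 1 boron, 2 oxygen; one six-membered aromatic ring of carbon only) in place of a group of 9 heavy atoms (6 carbon, 1 boron, 2 oxygen; one six-membered aromatic ring of carbon only), on a carbon with a double bond to nitrogen. Going by the values given here, no measured step covers a change of this kind, so the evidence is indirect. The measured steps are a 2.9-fold higher number from compound 2 to compound 3 (0.46 log units; beyond the scatter), which is modest, an 8.8-fold higher number from compound 1 to compound 2 (0.94 log units; beyond the scatter), also modest, and a 25-fold higher number from compound 1 to compound 3 (1.40 log units; beyond the scatter), which is large. Each of these exchanges one group for a different one, whereas here the atom count stays the same. A modest step or less is therefore expected in this assay. A slightly lower number is favoured, though only weakly, since compound 3 already stands at the top with 45100 nM. The expected change is a 1.5-fold lower number from compound 3 to compound 4 (0.18 log units; within the scatter). Compound 4 is estimated at 30000 nM, with an expected range of 10000 nM to 80000 nM.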

Compound 4, half-maximal inhibitory concentration: 18400 nM
For compound 4 the middle estimate is 1.6-fold (0.21 log units) above the measured one; the range from low to high includes it.
By their numbers in this assay, from the lowest: compound 1; then compounds 2 and 4 (each within the scatter of the next); then compound 3.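

Working notes: in this assay, the atoms alone do not fix the result, since exchanging the two isomeric groups on a carbon with a double bond to nitrogen gives a 2.5-fold lower number from compound 3 to compound 4 (0.39 log units; beyond the scatter) and is a change beyond the scatter with no change in atom count. The same exchange removes the separation from the aryl amide, with a 1.2-fold higher number from compound 2 to compound 4 (0.07 log units; within the scatter) on the amine nitrogen, so compound 4 cannot be told apart from compound 2 in this read-out. The rearrangement still leaves a wide gap to the bromo compound, with a 10-fold higher number from compound 1 to compound 4 (1.01 log units; beyond the scatter) as the remaining distance on that nitrogen.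

No supporting data bear on why the two isomers differ. On these data alone, whether a carboxylic acid or a nitrile in place of the boronic acid on the same aromatic ring would match compound 4 remains open.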